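The source may hold more compounds than are shown below. What is called first, only, known or untested is meant among the compounds shown, and "the series" means these compounds.

Compound 1 `CCc1cccc2c(OC)c(-c3occ(C)c3CO)ccc12` gives 9.6 ug/mL in a functional assay on A549 cells (Homo sapiens) for cytotoxicity, read by MTT assay, with a stated time of 72 h; a lower number here means that less compound is needed, a higher number that more compound is needed for the effect. Compound 2 `CCc1cccc2c(OC)c(-c3occ(C)c3COC)ccc12` gives in this assay only the limit > 10 ug/mL. Compound 3 `CCOCc1c(C)coc1-c1ccc2c(CC)cccc2c1OC` gives in this assay only the limit > 10 ug/mL.

Compound 3 therefore stands at a limit rather than a number, (the limit of > 10 ug/mL in this assay, at which 2 of the 3 values shown sit). Compound 4 `CCc1cccc2c(OC)c(-c3occ(C)c3COC(C)=O)ccc12` differs from compound 3 by acetyl in place of ethyl on an oxygen on a saturated carbon. Among the compounds with values here, the steps that bear on this change are an at least 1.0-fold higher number from compound 1 to compound 3 (0.01 log units; that floor lies within the scatter) and a step that the two limits leave unreadable from compound 2 to compound 3, both ending at a limit and so giving no readable size. For this assay he expects no step beyond the scatter, and the estimated step is a step that the limit leaves unreadable from compound 3 to compound 4. Compound 4 is estimated at 12 ug/mL, with a range from 6 ug/mL to 30 ug/mL.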

Compound 4, concentration for half-maximal effect: > 10 ug/mL
Compound 4 was reported as a limit; the forecaster's own chance of this, stated with the estimate: 60%; the middle value lies beyond the limit too.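

With acetyl on the oxygen on a saturated carbon, compound 4 also gives only a limit in this assay, so a group carrying a carbonyl joins methyl and ethyl in this place. Against hydrogen on this oxygen, the change is an at least 1.0-fold higher number from compound 1 to compound 4 (0.01 log units; that floor lies within the scatter), and the steps among the compounds at the limit cannot be read. Three different groups on this oxygen now end alike: the limit of > 10 ug/mL in this assay, at which 3 of the 4 values shown sit.

On these data alone, how far compound 2, compound 3 and compound 4 lie beyond that limit stays open. So does what an amine or a carboxylic acid in this place would give in this assay.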